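Chloro for Trifluoromethyl on the Urea Aryl Group

The source may hold more compounds than are shown below. What is called first, only, known or untested is meant among the compounds shown, and "the series" means these compounds.

Three measured compounds share one core. Compound 1 `O=C(Nc1cccc(-n2cc(-c3ccncc3)c(-c3cc(O)cc(Cl)c3)n2)c1)Nc1ccc(Cl)c(C(F)(F)F)c1` carries a trifluoromethyl group and a free hydroxyl, compound 2 `O=C(Nc1cccc(-n2cc(-c3ccncc3)c(-c3cc(O)cc(Cl)c3)n2)c1)Nc1ccc(Cl)c(Cl)c1` a chloro group in its place, and compound 3 `COc1cc(Cl)cc(-c2nn(-c3cccc(NC(=O)Nc4ccc(Cl)c(C(F)(F)F)c4)c3)cc2-c2ccncc2)c1` a methoxy group instead of the hydroxyl. In a functional assay on A498 cells (Homo sapiens) for inhibition, read by sulforhodamine B assay, with a stated time of 48 h, tested at 1 uM (on this read-out higher numbers stand for a weaker effect at the one concentration tested and lower numbers for a stronger effect), compound 1 gives 92%. In this assay compound 2 gives 75%. In this assay compound 3 gives 78%, the second highest of the three numbers; compound 2 sits within the scatter of it, compound 1 beyond the scatter above it. The two single changes give a number 17 percentage points lower from compound 1 to compound 2 (beyond the scatter) and a number 14 percentage points lower from compound 1 to compound 3 (beyond the scatter).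

Compound 4 `COc1cc(Cl)cc(-c2nn(-c3cccc(NC(=O)Nc4ccc(Cl)c(Cl)c4)c3)cc2-c2ccncc2)c1` has not been measured. It differs from compound 3 as follows: chloro in place of trifluoromethyl on an aromatic carbon. The same change has already been seen once, giving a number 17 percentage points lower from compound 1 to compound 2 (beyond the scatter), so a modest lowering beyond the scatter is expected in this assay, namely a number 15 percentage points lower from compound 3 to compound 4 (beyond the scatter). Compound 4 is therefore estimated at 63%, with a range from 50% to 76%.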

Compound 4, a percentage reported as activity, at one concentration (the size of the read-out at that concentration, not a potency): 73%
Compound 4: the middle estimate sits 10 percentage points below what was measured; the range from low to high includes it.
By their numbers in this assay, from the lowest: compounds 4, 2 and 3 (each within the scatter of the next); then compound 1.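

With the methoxy group in place, chloro in place of trifluoromethyl gives a number 5 percentage points lower from compound 3 to compound 4 (within the scatter) in this assay, so the change no longer produces a step beyond the scatter, yet its two readings cannot be told apart: the same change on two cores in this assay, a number 17 percentage points lower (beyond the scatter) from compound 1 to compound 2 and a number 5 percentage points lower (within the scatter) from compound 3 to compound 4, 12 percentage points apart, within the scatter of two such steps. With chloro in place, methyl on the hydroxyl oxygen likewise gives a number 2 percentage points lower from compound 2 to compound 4 (within the scatter), and this step also cannot be told apart from its counterpart: the same change on two cores in this assay, a number 14 percentage points lower (beyond the scatter) from compound 1 to compound 3 and a number 2 percentage points lower (within the scatter) from compound 2 to compound 4, 12 percentage points apart, within the scatter of two such steps. The four compounds therefore give no firm sign that either change depends on the other.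

The compounds shown leave open how a bromo, methyl or nitrile group would read in place of the chloro or trifluoromethyl group, and how an amine or a carboxylic acid would read in place of the hydroxyl. Each number tells only of a stronger or weaker effect at the one concentration tested.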